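The source may report more compounds than this note shows. Statements on the series, on what has been measured and on what is new or still open speak of the compounds shown alone.

Working notes on the series.

Within the data shown here, compound 1 `CN(Cc1ccc(F)cc1)C(=O)c1cc2c(Cc3ccccc3)n[nH]c2cc1O` stands highest of the two numbers so far measured in a functional assay on A2780 cells (Homo sapiens) for antiproliferative activity, read by resazurin assay, with a stated time of 72 h (on this read-out higher numbers stand for weaker inhibition and lower numbers for stronger inhibition), where compound 1 gives 4100 nM. Its nearest neighbour is compound 2 `CCOc1ccc(CN(C)C(=O)c2cc3c(Cc4ccccc4)n[nH]c3cc2O)cc1`, which in this assay gives 3200 nM; the step of a 1.3-fold lower number from compound 1 to compound 2 (0.11 log units; within the scatter) is within the scatter, so the two values cannot be ordered.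

Compound 3 `CN(Cc1ccc(F)cc1)C(=O)c1cc2c(Cc3cccc(Cl)c3)n[nH]c2cc1O` differs from compound 1 by chloro in place of hydrogen on an aromatic carbon, that is, phenyl to 3-chlorophenyl on the benzyl carried by the shared core. Among the measured compounds shown here, no measured step touches this benzyl; the only step in hand, ethoxy in place of fluoro, sits on the other benzyl and was within the scatter. Nothing in the measured compounds therefore points to a step beyond the scatter in this assay in either direction for compound 3, and the expectation rests on compound 1 alone.

Compound 3 is expected in this assay at 4000 nM, in the range 1500 nM to 10000 nM, an expected step of a 1.0-fold lower number from compound 1 to compound 3 (0.01 log units; within the scatter).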

Compound 3, half-maximal inhibitory concentration: 410 nM
Compound 3: middle estimate off by 9.8-fold (0.99 log units), on the high side; measured number below the stated range.
By their numbers in this assay, from the lowest: compound 3; then compounds 2 and 1 (each within the scatter of the next).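

Chloro in place of hydrogen on an aromatic carbon of the benzyl carried by the shared core gives a 10-fold lower number from compound 1 to compound 3 (1.00 log units; beyond the scatter) in this assay and is the first step in the series beyond the scatter. Among these compounds, the only earlier step, ethoxy in place of fluoro on the other benzyl, stayed within the scatter, so the series now holds a single-atom change at this benzyl that moves the number clearly, on one pair of compounds. Nothing measured on these compounds bears on the reason for a step of this size.

On these data alone, whether the step belongs to chloro itself or would also follow from a methyl, a methoxy or a fluoro on the same carbon stays open. Also open, as far as these compounds go, is whether it carries over to the ethoxy-bearing compound 2, and whether chloro on another carbon of that ring would give the same result.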